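The source may report more compounds than this note shows. Statements on the series, on what has been measured and on what is new or still open speak of the compounds shown alone.

In a functional assay on DU-145 cells (Homo sapiens) for cytotoxicity, read by MTT assay (a lower number here means a stronger inhibitor, a higher number a weaker inhibitor), compound 3 `CCC(C)(O)CC(=O)O[C@H](CC=C(C)C)C1=CC(=O)c2c(O)ccc(O)c2C1=O` gives 16000 nM. That sits within the scatter of compound 2 `CC(C)=CC[C@@H](OC(=O)C1CCCCO1)C1=CC(=O)c2c(O)ccc(O)c2C1=O` at 24700 nM, and clearly apart from compound 1 `CCCCC(O)CC(=O)O[C@H](CC=C(C)C)C1=CC(=O)c2c(O)ccc(O)c2C1=O` at 45300 nM. The next change leads to compound 4 `CC(C)=CC[C@@H](OC(=O)C1CCCOC1)C1=CC(=O)c2c(O)ccc(O)c2C1=O`: oxan-3-yl in place of 2-hydroxy-2-methylbutyl on a carbonyl carbon, (oxan-3-yl in place of 2-hydroxy-2-methylbutyl on a carbonyl carbon). The closest measured parallel is compound 2, which carries oxan-2-yl, and swapping that group for the open chain gave a 1.5-fold lower number from compound 2 to compound 3 (0.19 log units; within the scatter). The other steps are a 1.8-fold lower number from compound 1 to compound 2 (0.26 log units; within the scatter) and a 2.8-fold lower number from compound 1 to compound 3 (0.45 log units; beyond the scatter), so even the widest gap here is modest. The expected step is therefore a 1.4-fold higher number from compound 3 to compound 4 (0.14 log units; within the scatter), with nothing beyond the scatter anticipated. Compound 4 is estimated at 22000 nM, with an expected range of 9000 nM to 50000 nM.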

Compound 4, half-maximal inhibitory concentration: 29700 nM
For compound 4 the middle estimate is 1.4-fold (0.13 log units) below the measured one; the measured number falls inside the stated range.
By their numbers in this assay, from the lowest: compounds 3, 2, 4 and 1 (each within the scatter of the next, the first and the last beyond it).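

In this assay the open chain can give way to a ring that has no hydrogen-bond donor: oxan-3-yl in place of 2-hydroxy-2-methylbutyl stays within the scatter (a 1.9-fold higher number from compound 3 to compound 4 (0.27 log units; within the scatter)). The same holds for the ring oxygen's place, oxan-3-yl against oxan-2-yl (a 1.2-fold higher number from compound 2 to compound 4 (0.08 log units; within the scatter)), and for oxan-3-yl against 2-hydroxyhexyl (a 1.5-fold lower number from compound 1 to compound 4 (0.18 log units; within the scatter)), so the only clear gap remains the one between the two open chains. Nothing available explains these numbers. As far as these compounds go, whether an amine or a carboxylic acid on this carbonyl carbon would move the number beyond the scatter remains open.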